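The source may hold more compounds than are shown below. What is called first, only, known or untested is meant among the compounds shown, and "the series" means these compounds.

Of the compounds shown here, three have been measured in a functional assay on HT-1080 cells (Homo sapiens), read by MTT assay; on this read-out higher numbers stand for weaker inhibition and lower numbers for stronger inhibition. Compound 1 `Nc1nc(-c2cccs2)c2ncn([C@H]3C[C@H](O)[C@@H](CO)O3)c2n1` gives 38000 nM in this assay. Compound 2 `Nc1nc(-c2cccs2)c2ncn([C@@H]3O[C@H](CO)[C@@H](O)[C@H]3O)c2n1` carries a hydroxy where compound 1 carries a hydrogen, and in this assay compound 2 gives 88000 nM. The change from compound 2 to compound 1 is hydrogen in place of hydroxy on a saturated ring carbon, and it produced a 2.3-fold lower number from compound 2 to compound 1 (0.36 log units; beyond the scatter). Compound 3 `OC[C@H]1O[C@@H](n2cnc3c(-c4cccs4)ccnc32)[C@H](O)[C@@H]1O` is built on a different core, and the difference between the two cores is not broken down here. In this assay compound 3 gives 190000 nM, the highest of the three numbers. Compound 4 `OC[C@H]1O[C@@H](n2cnc3c(-c4cccs4)ccnc32)C[C@@H]1O` is the not yet measured partner of compound 3, made by the same change, (hydrogen in place of hydroxy on a saturated ring carbon), at a place described in exactly the same words as before. Because that change gave a 2.3-fold lower number from compound 2 to compound 1 (0.36 log units; beyond the scatter) on the first core, a step of similar size is expected on the second, a 2.2-fold lower number from compound 3 to compound 4 (0.35 log units; beyond the scatter). Compound 4 is therefore estimated at 85000 nM, with a likely range from 40000 nM to 200000 nM. That expectation rests on a single measured precedent, so the range is kept wide.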

Compound 4, half-maximal inhibitory concentration: 56000 nM
Beside the measured number, compound 4's estimate is 1.5-fold (0.18 log units) above it, and the stated range covers the measured number.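

Replacing the hydroxy with hydrogen on the second core gives a 3.4-fold lower number from compound 3 to compound 4 (0.53 log units; beyond the scatter) in this assay. Set beside the earlier step, this one runs in the same direction, and the two sizes cannot be told apart: the same change on two cores in this assay, a 2.3-fold lower number (0.36 log units; beyond the scatter) from compound 2 to compound 1 and a 3.4-fold lower number (0.53 log units; beyond the scatter) from compound 3 to compound 4, 1.5-fold (0.17 log units) apart, within the scatter of two such steps. Across these two pairs, then, the change carries over from one core to the other with a similar effect on the number, but two pairs in a single cell assay do not show why the number falls or that the same step would appear on a further core.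

Only hydroxy and hydrogen appear on this saturated ring carbon, which leaves open what an amine, a methoxy group or a fluorine atom would do there. Also open, going by these compounds, is how the number would respond if the hydroxymethyl group on the same ring gave way to a longer chain or a carboxylic acid.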